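The compounds below may be only part of what the source reports. "The series", "measured", "known", "first", "only" and "open" are said of these compounds alone.

Readings in an ADME assay for permeability, using PAMPA; a higher number here means that the compound crosses the layer faster, a lower number that the compound crosses the layer more slowly:
- compound 1 `COc1cc(N2CCN(C(=O)N3CCN(C)CC3)CC2)ccc1Nc1nc(NC2CCCCC2)c2nc[nH]c2n1`: "impermeable" (no number reported)
- compound 2 `COc1cc(N2CCN(Cc3ccccn3)CC2)ccc1Nc1nc(NC2CCCCC2)c2nc[nH]c2n1`: 976 10^-6 cm/s
- compound 3 `COc1cc(N2CCC(C(=O)N3CCOCC3)CC2)ccc1Nc1nc(NC2CCCCC2)c2nc[nH]c2n1`: 744 10^-6 cm/s

Among the measured compounds shown here, only two compounds carry a number. Compound 3 at 744 10^-6 cm/s lies within the scatter of compound 2 at 976 10^-6 cm/s, while compound 1 has no number to compare.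

Compound 4 `COc1cc(N2CCC(CC(=O)N3CCN(C)CC3)CC2)ccc1Nc1nc(NC2CCCCC2)c2nc[nH]c2n1` has not yet been measured. It differs from compound 3 on a saturated ring carbon of a six-membered non-aromatic ring with 1 nitrogen: ((4-methylpiperazin-1-yl)carbonyl)methyl in place of (morpholin-4-yl)carbonyl on a saturated ring carbon.

For the measured compounds named here, no measured pair differs in one place, so the size of this step has no direct precedent. Going by the values given here, the only guide is compound 1, which also carries a (4-methylpiperazin-1-yl)carbonyl group and reads "impermeable" (no number reported) in this assay. That single reading points to a downward move, though it is weak evidence. The expected change is a 3.0-fold lower number from compound 3 to compound 4 (0.47 log units; beyond the scatter). A result without a number, as for compound 1, also remains possible. For compound 4 the estimated value is 250 10^-6 cm/s, with an expected range of 30 10^-6 cm/s to 800 10^-6 cm/s.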

Compound 4, apparent permeability: 530 10^-6 cm/s
Compound 4: middle estimate off by 2.1-fold (0.33 log units), on the low side; the measured number falls inside the stated range.
By their numbers in this assay, from the lowest: compounds 4, 3 and 2 (each within the scatter of the next).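

In this assay, the step of a 1.4-fold lower number from compound 3 to compound 4 (0.15 log units; within the scatter) shows that this saturated ring carbon accepts ((4-methylpiperazin-1-yl)carbonyl)methyl in place of (morpholin-4-yl)carbonyl with no change beyond the scatter, even though the group entering is larger, at 10 heavy atoms against 8. A number is therefore obtainable in this series with a (4-methylpiperazin-1-yl)carbonyl unit in the side chain, here at this ring position. No available evidence accounts for this outcome.

The step combines a swap of the terminal ring with the insertion of a methyl link, so the two changes cannot be told apart; ((morpholin-4-yl)carbonyl)methyl or (4-methylpiperazin-1-yl)carbonyl on this same carbon would separate them. The compounds shown also leave open how a carboxylic acid or a primary amine at this position would read.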